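The source may report more compounds than this note shows. Statements on the series, on what has been measured and on what is new or still open speak of the compounds shown alone.

The measured compounds in this set:
Compound 1 `O=S(=O)(CCC(F)(Cl)C(F)(F)Cl)c1nc2ccccc2s1` gives 10100 nM.
Compound 3 `O=S(=O)(CCC(F)(Cl)C(F)(F)Cl)c1nc2ccc(Cl)cc2s1` gives 8400 nM.
Compound 2 `FC(F)(Cl)C(F)(Cl)CCSc1nc2ccc(Cl)cc2s1` reaches only a limit of the assay, not a number, at > 120000 nM.

All three were tested in a functional assay on MCF7 cells (Homo sapiens) for cytotoxicity, read by MTT assay, with a stated time of 48 h; on this read-out higher numbers stand for weaker inhibition and lower numbers for stronger inhibition. Compound 3 and compound 1 share a core and differ in one place, (hydrogen in place of chloro on an aromatic carbon), and the measured step was a 1.2-fold higher number from compound 3 to compound 1 (0.08 log units; within the scatter). Compound 2 carries a different core from compound 3, and that difference is not broken down here; what is known is that compound 2 sits at the limit of > 120000 nM in this assay, at which 1 of the 3 values shown sits, while compound 3 returns a number.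

Compound 4 `FC(F)(Cl)C(F)(Cl)CCSc1nc2ccccc2s1` is not yet measured. It differs from compound 2 by hydrogen in place of chloro on an aromatic carbon, the same change seen from compound 3 to compound 1. Resting on the earlier step, a 1.2-fold higher number from compound 3 to compound 1 (0.08 log units; within the scatter), the step from compound 2 to compound 4 in this assay is expected to be a step that the limit leaves unreadable from compound 2 to compound 4. Compound 4 is accordingly estimated at about 150000 nM, between 60000 nM and 400000 nM, and it may well again return only a limit.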

Compound 4, half-maximal inhibitory concentration: > 120000 nM
Compound 4 ended at the assay's limit; the forecaster's own chance of this, stated with the estimate: 70%; the middle value is on the limit's open side.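

Going by these compounds alone, compound 2 and compound 4 both end at a limit of the assay rather than at a number, so no step between them can be read: the limit of > 120000 nM in this assay, at which 2 of the 4 values shown sit. The compounds shown leave open what numbers these two would return, and whether hydrogen in place of chloro on an aromatic carbon changes anything on their shared core.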